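The compounds below may be only part of what the source reports. "The series", "measured", "known", "first", "only" and "open" are said of these compounds alone.

Compound 1 `N/C(=N\NC(=S)N1CCCCCC1)c1ccccn1` gives 50.3% in a functional assay on A-431 cells (Homo sapiens) for cytotoxicity, read by MTT assay, with a stated time of 72 h, tested at 3 uM; on this read-out higher numbers stand for more inhibition of growth at the one concentration tested and lower numbers for less inhibition of growth. Compound 2 `N/C(=N\NC(=S)N1CCSCC1)c1ccccn1` gives 37.2% in this assay, and compound 3 `N/C(=N\NC(=S)N1CCSCC1)c1ccc(F)cn1` gives 61.2%. The difference between the cores of compound 1 and compound 2 is not broken down here. The change from compound 2 to compound 3 is fluoro in place of hydrogen on an aromatic carbon and it made a step of a number 24 percentage points higher from compound 2 to compound 3 (beyond the scatter) in this assay. Compound 4 `N/C(=N\NC(=S)N1CCCCCC1)c1ccc(F)cn1` has not yet been measured. It differs from compound 1 by fluoro in place of hydrogen on an aromatic carbon, which is the same change at the same place as that made between compound 2 and compound 3. Beside that earlier step, the step from compound 1 to compound 4 is expected to be a number 17.7 percentage points higher from compound 1 to compound 4 (beyond the scatter), resting on the single precedent a number 24 percentage points higher from compound 2 to compound 3 (beyond the scatter). Compound 4 is therefore estimated at 68%, between 52% and 84%.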

Compound 4, percent growth inhibition at one concentration: 62.4%
Compound 4: middle estimate off by 5.6 percentage points, on the high side; the measured number falls inside the stated range.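

In this assay fluoro in place of hydrogen on an aromatic carbon gave a number 12.1 percentage points higher from compound 1 to compound 4 (beyond the scatter) on the core of compound 1, so the change raised the read-out on both cores shown. The two steps cannot be told apart in size: the same change on two cores in this assay, a number 24 percentage points higher (beyond the scatter) from compound 2 to compound 3 and a number 12.1 percentage points higher (beyond the scatter) from compound 1 to compound 4, 11.9 percentage points apart, within the scatter of two such steps. This rests on just two pairs in a single assay at a single concentration, so it does not show that the change would carry to any further core, and it gives no reason for the rise.

The compounds shown leave open whether another group at the same place, such as chloro, methoxy or an amine, would give a similar step. They also leave open what fluoro would do at another place on the ring.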